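Bromo on the core of compound 1

The compounds below may be only part of what the source reports. "The series", "measured", "known", "first", "only" and "open" are said of these compounds alone.

Going by the values given here, in a functional assay on MDA-MB-231 cells (Homo sapiens) for cytotoxicity, read by sulforhodamine B assay, with a stated time of 72 h (on this read-out lower numbers stand for stronger inhibition of growth and higher numbers for weaker inhibition of growth), compound 1 `Cn1cc(C2CCN=C(N)N2)c2ccccc21` gives 1710 nM, the only number available so far. Compound 2 `COn1cc(C2CCN=C(N)N2)c2ccccc21` is reported as "not active" (no number reported), without a number. Compound 3 `Cn1cc(C2CCN=C(N)N2)c2ccc(Br)cc21` differs from compound 1 in one place, with bromo in place of hydrogen on an aromatic carbon. Among the compounds with values here, no measured step shows what such a change does, so the expectation is uncertain. A modest strengthening of growth inhibition is expected in this assay, with an estimated 2.1-fold lower number from compound 1 to compound 3 (0.33 log units; beyond the scatter). For compound 3, the expected value is 800 nM, with an estimated range of 280 nM to 2300 nM.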

Compound 3, concentration for 50% growth inhibition: 8790 nM
Estimate against measurement, compound 3: 11-fold (1.04 log units) below; the whole stated range lies below it.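

In this assay bromo in place of hydrogen gives a 5.1-fold higher number from compound 1 to compound 3 (0.71 log units; beyond the scatter) and so weaker growth inhibition, the first sign that this aromatic carbon on the core of compound 1 responds to substitution. Compound 3 still gives a number, so this change weakens growth inhibition without abolishing it. Nothing measured here accounts for the shift.

From the compounds shown here alone, whether fluoro, an amine or a carboxylic acid on this same aromatic carbon would follow bromo stays open. A single substituent at a single place shows no trend, and the other carbons of this ring remain unexplored in the compounds shown.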